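The source may hold more compounds than are shown below. What is called first, only, known or untested is meant among the compounds shown, and "the series" means these compounds.

Working notes on the solubility series.

Compound 1 `Cc1c(O)c(=O)ccn1CCCc1cc(C(C)(C)C)c(O)c(C(C)(C)C)c1` is the reference point. In an ADME assay for solubility (a lower number here means a less soluble compound, a higher number a more soluble compound), compound 1 returns only a limit, < 100 ug/mL, so its true value is not resolved by this assay. Compound 2 `Cc1c(C)c2c(c(C)c1O)CCC(C)(CNCCCCn1ccc(=O)c(O)c1C)O2` sits at the same limit, giving < 100 ug/mL in this assay. Compound 3 `Cc1c(C)c2c(c(C)c1OC(=O)CN(C)C)CC(CCn1ccc(=O)c(O)c1C)O2` reaches the opposite limit of this assay, with > 20000 ug/mL reported. For the measured compounds named here, two of the three measurements thus fall at the limit of < 100 ug/mL in this assay, at which 2 of the 3 values shown sit, while one stands at the limit of > 20000 ug/mL in this assay, at which 1 of the 3 values shown sits; no pair of measured compounds differs in a single place, so no measured step can be drawn from these values, and the spread between compound 1 and compound 3 shows only that both ends of the assay window are occupied within this set.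

Compound 4 `Cc1c(OC(=O)c2ccc(N)cc2)c(=O)ccn1CCCc1cc(C(C)(C)C)c(O)c(C(C)(C)C)c1` has not yet been measured in this assay. It differs from compound 1 by (4-aminophenyl)carbonyl in place of hydrogen on an oxygen on an aromatic ring; one bond further out, the change reads hydroxy to ((4-aminophenyl)carbonyl)oxy. Because compound 1 already sits at the limit of < 100 ug/mL in this assay, at which 2 of the 3 values shown sit, the step is expected to remain below the resolving range of this assay, with any movement in the downward direction or none beyond the scatter. The estimate for compound 4 is 30 ug/mL in this assay, within 5 ug/mL to 100 ug/mL, which corresponds to an expected step that the limit leaves unreadable from compound 1 to compound 4; another limit report is the most likely outcome.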

Compound 4, solubility: < 100 ug/mL
Compound 4: a limit, no number; the forecaster's own chance of this, stated with the estimate: 85%; the middle value lies beyond the limit too.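

In this assay compound 4 returns < 100 ug/mL, which is a limit; compound 1 also returns only a limit, so no step can be read between compound 1 and compound 4. The compounds shown leave open whether (4-aminophenyl)carbonyl in place of hydrogen on an oxygen on an aromatic ring changes solubility at all.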